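Series notes: imidazole pendant aryl variation at bombesin receptor subtype-3

This account rests on a few compounds, and the source may have more. Where it says the series, first, only, none or still open, it means among the compounds named here.

Measured compounds:
- compound 1 `O=C(O)c1ccccc1-c1ccc(CCc2ncc(Cc3ccccc3Cl)[nH]2)cc1` gives 292 nM in an in vitro functional assay on cells for agonist activity at Bombesin receptor subtype-3 (Homo sapiens), read by luminescence and calcium flux; on this read-out lower numbers stand for an effect already at smaller amounts and higher numbers for an effect only at larger amounts of compound
- compound 2 `O=C(O)c1ccccc1-c1ccc(CCc2ncc(CCc3ccccc3)[nH]2)cc1` gives 1320 nM in this assay
- compound 3 `O=C(O)c1ccccc1-c1ccc(CCc2ncc(Cc3cccc(F)c3F)[nH]2)cc1` gives 87 nM in this assay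

Compound 3 has the lowest number of the three in this assay; compound 1 is nearest to it, compound 2 furthest, both steps beyond the scatter. Compound 4 `Cc1ccc(Cc2cnc(CCc3ccc(-c4ccccc4C(=O)O)cc3)[nH]2)cc1` is not yet measured. The change from compound 3 is 4-methylphenyl in place of 2,3-difluorophenyl on a saturated chain carbon bound to an aromatic carbon.

Within the data shown here, two measured steps bear on this change, since both end at the 2,3-difluorophenyl of compound 3. Replacing benzyl by that group gave a 15-fold lower number from compound 2 to compound 3 (1.18 log units; beyond the scatter), and replacing 2-chlorophenyl by it gave a 3.4-fold lower number from compound 1 to compound 3 (0.53 log units; beyond the scatter). The step from compound 3 to compound 4 runs the other way, from 2,3-difluorophenyl to an aryl that carries neither fluorine nor chlorine; the nearest measured analogue with such an unsubstituted pattern is compound 2, which gives 1320 nM. Among the measured compounds shown here, no measured compound carries a 4-methylphenyl, so the effect of the methyl is unknown.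

A higher number is therefore expected for compound 4, probably between the step seen for compound 1 and that seen for compound 2, i.e. a 6.9-fold higher number from compound 3 to compound 4 (0.84 log units; beyond the scatter). Compound 4 is estimated at 600 nM, with a range from 150 nM to 2500 nM.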

Compound 4, half-maximal effective concentration: 2660 nM
For compound 4 the middle estimate is 4.4-fold (0.65 log units) below the measured one, and the stated range ends below it.
By their numbers in this assay, from the lowest: compound 3; then compound 1; then compounds 2 and 4 (each within the scatter of the next).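

In this assay, the saturated chain carbon bound to an aromatic carbon proves sensitive to the substitution on the aryl group alone: with the six-membered aromatic ring kept, the change from 2,3-difluorophenyl to 4-methylphenyl gives a 31-fold higher number from compound 3 to compound 4 (1.49 log units; beyond the scatter). The 4-methylphenyl group also fails to match 2-chlorophenyl, at a 9.1-fold higher number from compound 1 to compound 4 (0.96 log units; beyond the scatter), so among the compounds shown, methyl on the ring does not stand in for either halogen pattern. Against benzyl the result is a 2.0-fold higher number from compound 2 to compound 4 (0.30 log units; within the scatter), which leaves compound 2 and compound 4 unseparated; across these four compounds, the lower numbers belong only to the halogen-bearing aryl groups of compound 1 and compound 3, and no compound shown goes against this.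

The compounds shown do not separate an effect of the methyl from an effect of removing the fluorines, and direct comparisons with plain phenyl, 4-fluorophenyl and 2-methylphenyl on this carbon would be needed to do so. No measurement at hand accounts for the size of these steps.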